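Swapping trimethoxyphenyl for bromophenyl on a shared core

This account rests on a few compounds, and the source may have more. Where it says the series, first, only, none or still open, it means among the compounds named here.

compound 1 `COc1cc(-c2cc(-c3ccc(C4NC(=O)c5ccccc5N4)cc3)nc(N)n2)cc(OC)c1OC` gives 103000 nM
compound 2 `CC(C)(C)n1nnnc1C(Nc1ccccc1)c1ccc(C2NC(=O)c3ccccc3N2)cc1` gives "not determined" (no result reported)
compound 3 `CCCCNc1nc(NCCCC)nc(Nc2ccc(C3(C)NC(=O)c4ccccc4N3)cc2)n1` gives 40100 nM

In an ADME assay on J774.A1 cells (Mus musculus) for cytotoxicity, read by MTT assay, with a stated time of 72 h (a higher number here means that more compound is tolerated, a lower number that less compound is tolerated), compound 1 has the higher of the two numbers, and compound 3 (40100 nM) lies lower by more than the usual scatter. Compound 2 offers no number for comparison. Compound 4 `Nc1nc(-c2ccc(Br)cc2)cc(-c2ccc(C3NC(=O)c4ccccc4N3)cc2)n1` keeps the core of compound 1 but carries 4-bromophenyl in place of 3,4,5-trimethoxyphenyl on an aromatic carbon. For the measured compounds named here, no measured pair shows this swap alone, so any expectation is loose. Going by the values given here, the only other number comes from compound 3 (40100 nM), whose structure differs more widely. A moderate fall in this assay is expected (a 2.3-fold lower number from compound 1 to compound 4 (0.36 log units; beyond the scatter)), meaning less compound tolerated. For compound 4 the value is estimated at 45000 nM with an expected range from 15000 nM to 120000 nM in repeated measurements.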

Compound 4, half-maximal cytotoxic concentration: 125000 nM
Compound 4: middle estimate off by 2.8-fold (0.44 log units), on the low side; the measured number lies above the stated range.
By their numbers in this assay, from the lowest: compound 3; then compounds 1 and 4 (each within the scatter of the next).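

In this assay, the step at this aromatic carbon, 4-bromophenyl in place of 3,4,5-trimethoxyphenyl, reads a 1.2-fold higher number from compound 1 to compound 4 (0.08 log units; within the scatter). This position therefore accepts a smaller group without hydrogen-bond acceptors, and the two numbers still cannot be told apart in this cell test. No measurement here explains this result. As far as these compounds go, whether a different kind of group at this position, such as an amine or a carboxylic acid, would give a clearly separate number remains open. From the compounds shown here alone, a longer alkyl chain there is an equally open case.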